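Amide variation on the shared core: compounds 1 to 4

This account rests on a few compounds, and the source may have more. Where it says the series, first, only, none or still open, it means among the compounds named here.

Measured so far:
compound 1 `CCC(=O)N(C)c1ccc2[nH]c(-c3n[nH]c4ccccc34)cc2n1` — 15700 nM
compound 2 `CN(C(=O)CCc1ccccc1)c1ccc2[nH]c(-c3n[nH]c4ccccc34)cc2n1` — 18100 nM
compound 3 `COc1cccc(C(=O)N(C)c2ccc3[nH]c(-c4n[nH]c5ccccc45)cc3n2)c1` — 14900 nM

All three numbers come from a functional assay on A549 cells (Homo sapiens) for antiproliferative activity, read by MTT assay, with a stated time of 72 h; on this read-out higher numbers stand for weaker inhibition and lower numbers for stronger inhibition. Compound 3 has the lowest of the three numbers, but its steps to the others are small: a 1.1-fold lower number from compound 1 to compound 3 (0.02 log units; within the scatter) and a 1.2-fold lower number from compound 2 to compound 3 (0.08 log units; within the scatter) both lie within the scatter, as does a 1.2-fold higher number from compound 1 to compound 2 (0.06 log units; within the scatter). Within the data shown here, on these numbers the three compounds cannot be told apart, and no compound can be called the more active.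

Compound 4 `CN(C(=O)c1ccc([N+](=O)[O-])cc1)c1ccc2[nH]c(-c3n[nH]c4ccccc34)cc2n1` is the next member. It differs from compound 3 by 4-nitrophenyl in place of 3-methoxyphenyl on a carbonyl carbon. Among the measured compounds shown here, the steps that bear on this change are those that also vary the group on the carbonyl carbon, a 1.1-fold lower number from compound 1 to compound 3 (0.02 log units; within the scatter) and a 1.2-fold lower number from compound 2 to compound 3 (0.08 log units; within the scatter); both are within the scatter, and the group on the carbonyl carbon has so far left this assay unmoved across an ethyl, a phenethyl and a 3-methoxyphenyl. For the measured compounds named here, a 4-nitrophenyl is a fourth group at the same place; no measured step speaks for a shift in either direction.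

For compound 4 the expected step is therefore a 1.0-fold higher number from compound 3 to compound 4 (0.02 log units; within the scatter), none beyond the scatter. The estimate for compound 4 in this assay is 15500 nM, with a range from 5500 nM to 45000 nM.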

Compound 4, half-maximal inhibitory concentration: 34500 nM
Compound 4: middle estimate off by 2.2-fold (0.35 log units), on the low side, within the range that was stated.
By their numbers in this assay, from the lowest: compounds 3, 1, 2 and 4 (each within the scatter of the next, the first and the last beyond it).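

In this assay, among these compounds, the group on the carbonyl carbon now makes a readable difference for the first time: 4-nitrophenyl in place of 3-methoxyphenyl gives a modest step (a 2.3-fold higher number from compound 3 to compound 4 (0.36 log units; beyond the scatter)), and 4-nitrophenyl in place of ethyl gives another (a 2.2-fold higher number from compound 1 to compound 4 (0.34 log units; beyond the scatter)). The separation is incomplete, as 4-nitrophenyl in place of phenethyl stays within the scatter (a 1.9-fold higher number from compound 2 to compound 4 (0.28 log units; within the scatter)), so compound 4 is set apart from only two of the three earlier compounds. No measurement shown accounts for this shift.

One nitro-bearing compound cannot show whether the nitro group or its ring position carries the step. A 3-nitrophenyl, a 4-methoxyphenyl or a 4-aminophenyl on the same carbonyl carbon would leave that open question better defined.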